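A Bromoethoxyphenyl Variant on the Nitrothiophene Lead

A few compounds are considered here, and "the series" means these few. Any claim that something is new, unique, unknown or untested is made for them only; others in the source may bear on it.

Going by the values given here, compound 2, `Cc1oc2c([C@H]3CCN(C)C[C@H]3O)c(O)cc(O)c2c(=O)c1C(O)c1csc([N+](=O)[O-])c1`, is the stronger of the two compounds measured so far in a functional assay on HL-60 cells (Homo sapiens) for inhibition, read by MTT assay, with a stated time of 48 h, tested at 10 uM (a lower number here means less inhibition of growth, a higher number more inhibition of growth at the concentration tested), where it gives 45%. Among the compounds with values here, its only companion, compound 1, `Cc1oc2c([C@H]3CCN(C)C[C@H]3O)c(O)cc(O)c2c(=O)c1C(O)c1ccc(F)c(Br)c1`, gives 25% in this assay; the step from the one to the other, a number 20 percentage points higher from compound 1 to compound 2 (beyond the scatter), is the single measured change in this set. Compound 3, `CCOc1ccc(Br)c(C(O)c2c(C)oc3c([C@H]4CCN(C)C[C@H]4O)c(O)cc(O)c3c2=O)c1`, is not yet measured. It differs from compound 2 in one place: 2-bromo-5-ethoxyphenyl in place of 5-nitrothiophen-3-yl on a saturated chain carbon bound to an aromatic carbon and an oxygen on a saturated carbon. The change thus puts back a six-membered aromatic ring of carbon only carrying a bromine, much as in compound 1, in place of the five-membered ring with a nitro group that set compound 2 apart. Within the data shown here, the one step that bears on this, a number 20 percentage points higher from compound 1 to compound 2 (beyond the scatter), ran in the opposite direction when the nitrothiophene came in, so a drop of similar size is expected when it leaves again, a number 17 percentage points lower from compound 2 to compound 3 (beyond the scatter). Compound 3 is therefore estimated at 28% in this assay, with a likely range from 15% to 45%.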

Compound 3, percent growth inhibition at one concentration: 2%
Beside the measured number, compound 3's estimate is 26 percentage points above it; measured number below the stated range.
By their numbers in this assay, from the lowest: compound 3; then compound 1; then compound 2.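

In this assay, going by these compounds alone, this position proves more sensitive than the single earlier step could show, with a number 43 percentage points lower from compound 2 to compound 3 (beyond the scatter) and also a number 23 percentage points lower from compound 1 to compound 3 (beyond the scatter) as the two new readings. The second of these steps is the more telling one: 3-bromo-4-fluorophenyl and 2-bromo-5-ethoxyphenyl are both six-membered aromatic rings of carbon only that carry a bromine, yet they do not give the same result, so swapping the five-membered ring for a six-membered one does not by itself restore the level of compound 1. What matters here includes the groups on the ring and where they sit, not only the kind of ring. No measurement at hand offers an explanation for either step.

Compound 1 and compound 3 differ in both the second group on the ring and the placing of the bromine, so the compounds shown cannot say which of these changes matters, or whether both do. On these data alone, how a plain phenyl, an unsubstituted thiophene, or a phenyl carrying an amine or a carboxylic acid would behave at this position also remains open.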